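Propargyl for Allyl Amides: Whole-Animal Toxicity Compared

A few compounds are considered here, and "the series" means these few. Any claim that something is new, unique, unknown or untested is made for them only; others in the source may bear on it.

Four amides share an unsaturated chain carrying a carbonyl, an amide nitrogen and a short chain on that nitrogen, and differ in the aromatic ring and in that chain. Compound 1 `C#CCNC(=O)/C(C)=C(\C)c1ccc(Br)cc1` and compound 2 `C=CCNC(=O)/C(C)=C(\C)c1ccc(Br)cc1` carry the same core; compound 3 `C=CCNC(=O)/C(C)=C(\C)c1cc(OC)c(OC)c(OC)c1` and compound 4 `C#CCNC(=O)/C(C)=C(\C)c1cc(OC)c(OC)c(OC)c1` carry a second core. The difference between the two cores is not broken down here.

In a toxicity assay on the whole organism (strain Icem-CET (SPF Caw)) for cytotoxicity, with Mus musculus as the target (a higher number here means that more compound is needed for the effect, a lower number that less compound is needed), compound 2 gives 500 mg/kg, while compound 1 gives 150 mg/kg. The change between them, (ethynyl in place of vinyl on a saturated chain carbon bound to an amide-type nitrogen), made a step of a 3.3-fold lower number from compound 2 to compound 1 (0.52 log units; beyond the scatter).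

Compound 3 gives 190 mg/kg in this assay. Against compound 1 this is a gap within the scatter, so no order between those two is claimed; against compound 2 the gap lies beyond the scatter.

Compound 4 differs from compound 3 by ethynyl in place of vinyl on a saturated chain carbon bound to an amide-type nitrogen. For the measured compounds named here, this is the same change, at the same place, as the one from compound 2 to compound 1. Because compound 1 sits a 3.3-fold lower number from compound 2 to compound 1 (0.52 log units; beyond the scatter) away from compound 2, a step of similar direction and size is expected here, tempered by the fact that the core is different and the change has been seen only once. The expected step is a 2.9-fold lower number from compound 3 to compound 4 (0.47 log units; beyond the scatter). Compound 4 is therefore estimated at 65 mg/kg in this assay, most likely between 30 mg/kg and 150 mg/kg.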

Compound 4, dose for half-maximal effect: 150 mg/kg
Compound 4: the middle estimate sits 2.3-fold (0.36 log units) below what was measured; low and high end bracket the measured number.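

In this assay, the swap of vinyl for ethynyl on the second core gives a 1.3-fold lower number from compound 3 to compound 4 (0.10 log units; within the scatter), so on this core the change produces no difference that can be told apart from the ordinary spread of repeat measurements. For the compounds shown here, although only one of the two steps lies beyond the scatter, the steps themselves cannot be told apart, so the result gives no firm sign that the core alters the effect of this change: the same change on two cores in this assay, a 3.3-fold lower number (0.52 log units; beyond the scatter) from compound 2 to compound 1 and a 1.3-fold lower number (0.10 log units; within the scatter) from compound 3 to compound 4, 2.6-fold (0.42 log units) apart, within the scatter of two such steps. What this does not show is that the change carries over reliably from one core to another, since two pairs cannot separate a true dependence on the core from measurement spread, and the clear step on the first core has no clear counterpart on the second.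

The compounds shown leave open how a saturated propyl chain or a longer chain on the amide nitrogen would compare with allyl and propargyl in this series. They also leave open whether the step would be clear or lost in the scatter on a third core, for instance an aromatic ring carrying a nitrile or a carboxylic acid.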